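From nitrophenyl amide to thiazolyl amide

This account rests on a few compounds, and the source may have more. Where it says the series, first, only, none or still open, it means among the compounds named here.

In a functional assay on Bel-7402 cells (Homo sapiens) for cytotoxicity, read by MTT assay (on this read-out lower numbers stand for stronger inhibition and higher numbers for weaker inhibition), compound 3 `CCn1cc(C(=O)Nc2cc([N+](=O)[O-])ccc2F)c(=O)c2cc(F)c(N3CCNC(C)C3)c(F)c21` gives 2900 nM, within the scatter of compound 1 `CCn1cc(-c2nc3ccc([N+](=O)[O-])cc3o2)c(=O)c2cc(F)c(N3CCNC(C)C3)c(F)c21` at 1600 nM and well short of compound 2 `CCn1cc(C(=O)Nc2ccc(C)c([N+](=O)[O-])c2)c(=O)c2cc(F)c(N3CCNC(C)C3)c(F)c21` at 29100 nM. Compound 4 `CCn1cc(C(=O)Nc2nccs2)c(=O)c2cc(F)c(N3CCNC(C)C3)c(F)c21` differs from compound 3 by 1,3-thiazol-2-yl in place of 2-fluoro-5-nitrophenyl on an amide-type nitrogen; in words, 1,3-thiazol-2-yl stands in place of 2-fluoro-5-nitrophenyl on an amide-type nitrogen. For the measured compounds named here, only one measured step bears on this change: a 10-fold lower number from compound 2 to compound 3 (1.00 log units; beyond the scatter), which shows that the group on that nitrogen can move the number substantially. No amide carrying a thiazolyl group has been measured, so the direction remains uncertain. A smaller step towards a higher number is expected, estimated as a 2.1-fold higher number from compound 3 to compound 4 (0.32 log units; beyond the scatter). For compound 4 the estimate is 6000 nM, with an expected range from 1500 nM to 25000 nM.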

Compound 4, half-maximal inhibitory concentration: > 50000 nM
Compound 4 gave a limit, no number; the forecaster's own chance of this, stated with the estimate: 5%; at least 8.3-fold (0.92 log units) between middle value and limit.
By their numbers in this assay, from the lowest: compounds 1 and 3 (each within the scatter of the next); then compound 2. At a limit, above all of these: compound 4.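

In this assay, the 2-fluoro-5-nitrophenyl group on the amide-type nitrogen proves hard to replace: 1,3-thiazol-2-yl in its place gives an at least 17-fold higher number from compound 3 to compound 4 (1.23 log units; beyond the scatter). Set against the 4-methyl-3-nitrophenyl amide, the same group gives an at least 1.7-fold higher number from compound 2 to compound 4 (0.23 log units; that floor lies within the scatter), a floor that does not separate the two compounds. Compound 4 gives a limit, not a number: the limit of > 50000 nM in this assay, at which 1 of the 4 values shown sits.

The compounds shown leave open whether the smaller ring or the absence of the nitro group matters here. A plain phenyl on the same nitrogen would separate the two.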